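A few compounds are considered here, and "the series" means these few. Any claim that something is new, unique, unknown or untested is made for them only; others in the source may bear on it.

Compound 1 `O=C(O[C@H]1C[C@H](n2cc(F)c(=O)[nH]c2=O)O[C@@H]1COP(=O)(O)Oc1ccccc1)c1ccccc1`: 810 nM
Compound 2 `C[N+]1(C)CCC(OP(=O)([O-])OC[C@H]2O[C@@H](n3cc(F)c(=O)[nH]c3=O)C[C@@H]2OC(=O)c2ccccc2)CC1`: 6700 nM

On these two numbers in a functional assay on T98G cells (Homo sapiens) for cytotoxicity, read by MTT assay, with a stated time of 48 h (on this read-out lower numbers stand for stronger inhibition and higher numbers for weaker inhibition), compound 1 stands lowest, separated from compound 2 by the step of an 8.3-fold higher number from compound 1 to compound 2 (0.92 log units; beyond the scatter). Compound 3 `O=c1[nH]c(=O)n([C@H]2C[C@H](O)[C@@H](COP(=O)(O)Oc3ccccc3)O2)cc1F` is not yet measured. It differs from compound 1 by hydrogen in place of benzoyl on an oxygen on a saturated carbon, the benzoyloxy becoming hydroxy. Within the data shown here, the only measured step changes a different part of compound 1 and so does not bear on this change; no step at the benzoyl exists. A shift of uncertain direction, possibly beyond the scatter, is therefore expected, written as a 2.5-fold higher number from compound 1 to compound 3 (0.39 log units; beyond the scatter). Compound 3 is estimated at 2000 nM, with a range from 500 nM to 8000 nM.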

Compound 3, half-maximal inhibitory concentration: 32200 nM
Compound 3: middle estimate off by 16-fold (1.21 log units), on the low side; measured number outside the range, above it.
By their numbers in this assay, from the lowest: compound 1; then compound 2; then compound 3.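

In this assay, among these compounds, hydrogen in place of benzoyl on this oxygen gives a 40-fold higher number from compound 1 to compound 3 (1.60 log units; beyond the scatter), the first reading at this position, and a large one. The benzoyloxy of compound 1 therefore matters strongly here: among these compounds, the hydroxy form compound 3 has the highest number. No measurement available here accounts for this step.

As far as these compounds go, it remains open whether a smaller acetyl group or a longer-chain acyl group on this oxygen would keep the lower number. From the compounds shown here alone, it is equally open whether benzoyloxy to hydroxy would shift the number as far on the core of compound 2.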